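Hydroxy to Chloro on the Aryl Ring of a Shared Core

The compounds below may be only part of what the source reports. "The series", "measured", "known", "first", "only" and "open" are said of these compounds alone.

Compound 2 `CCOC(=O)c1cnn(-c2nc(-c3ccccc3O)c(C#N)c(=O)n2C)c1N` was tested in a functional assay, with a stated time of 20 min (a higher number here means a weaker inhibitor, a lower number a stronger inhibitor), and gave 48 ug/mL. Compound 1 `COc1ccc(-c2nc(NN)n(C)c(=O)c2C#N)cc1` gave 41 ug/mL in this assay, a number within the scatter of the result for compound 2, so the two compounds stand together. Among the compounds with values here, no step between measured compounds is available. Compound 3 `CCOC(=O)c1cnn(-c2nc(-c3ccccc3Cl)c(C#N)c(=O)n2C)c1N` differs from compound 2 by chloro in place of hydroxy on an aromatic carbon. Within the data shown here, with no comparable pair to guide the size of the change, the expectation for a 1.1-fold lower number from compound 2 to compound 3 (0.03 log units; within the scatter) is a step of no size beyond the scatter, in no particular direction. Compound 3 is therefore estimated at 45 ug/mL in this assay, within 18 ug/mL to 110 ug/mL.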

Compound 3, half-maximal inhibitory concentration: 78 ug/mL
For compound 3 the middle estimate is 1.7-fold (0.24 log units) below the measured one, and the stated range covers the measured number.
By their numbers in this assay, from the lowest: compounds 1, 2 and 3 (each within the scatter of the next).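

The swap of hydroxy for chloro gives a 1.6-fold higher number from compound 2 to compound 3 (0.21 log units; within the scatter) in this assay. This first comparison at a single place shows that, on an aromatic carbon ortho to a large group, a group with one hydrogen-bond donor and one acceptor can give way to one with neither, and the two compounds still stand together. Nothing measured bears on the reason for this result. Still open, on these data alone, is whether an amine or a carboxylic acid at this place would give a step beyond the scatter.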